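From compound 3 to compound 4: a new aryl group

This account rests on a few compounds, and the source may have more. Where it says the series, first, only, none or still open, it means among the compounds named here.

Compound 1 `CN1CCN(CC2CCN(c3nccc4[nH]c(-c5cccc(OC(F)(F)F)c5)nc34)CC2)CC1`: 200000 nM
Compound 2 `CN1CCN(CC2CCN(c3nccc4[nH]c(-c5ccc(F)c(Cl)c5)nc34)CC2)CC1`: 155000 nM
Compound 3 `CN1CCN(CC2CCN(c3nccc4[nH]c(-c5cc(F)cc(C(F)(F)F)c5)nc34)CC2)CC1`: 165000 nM

All three values come from a physicochemical assay for solubility, read by HPLC, using the shake flask method, in phosphate buffer, with a stated time of 20 h, at pH 6.5; on this read-out lower numbers stand for lower solubility and higher numbers for higher solubility. Compound 3, at 165000 nM, stands within the usual scatter of both other compounds, as shown by a 1.2-fold lower number from compound 1 to compound 3 (0.08 log units; within the scatter) and a 1.1-fold higher number from compound 2 to compound 3 (0.03 log units; within the scatter).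

The next molecule is compound 4 `CN1CCN(CC2CCN(c3nccc4[nH]c(-c5cccc(C(=O)N(C)C)c5)nc34)CC2)CC1`. It has 3-(dimethylcarbamoyl)phenyl in place of 3-fluoro-5-(trifluoromethyl)phenyl on an aromatic carbon.

The three measured steps all changed this same group, so all bear on the new change. The biggest of them, a 1.3-fold lower number from compound 1 to compound 2 (0.11 log units; within the scatter), still lies within the scatter. However, no measured compound carries a dimethylcarbamoyl group, so the data give no firm direction and the range must stay wide. The expected step is a 1.2-fold higher number from compound 3 to compound 4 (0.08 log units; within the scatter), which would remain within the scatter. Compound 4 is estimated at 200000 nM, with an expected range from 120000 nM to 350000 nM.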

Compound 4, solubility: 180000 nM
Beside the measured number, compound 4's estimate is 1.1-fold (0.05 log units) above it, and the stated range covers the measured number.
By their numbers in this assay, from the lowest: compounds 2, 3, 4 and 1 (each within the scatter of the next).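

In this assay, the aryl group on the carbon between two ring nitrogen atoms now carries a dimethylcarbamoyl group, the first in this set without any halogen and with a carbonyl, yet every comparison stays within the scatter: a 1.1-fold higher number from compound 3 to compound 4 (0.04 log units; within the scatter) and a 1.2-fold higher number from compound 2 to compound 4 (0.06 log units; within the scatter) and a 1.1-fold lower number from compound 1 to compound 4 (0.05 log units; within the scatter). Going by these compounds alone, the earlier compounds showed only that halogen-bearing aryl groups are alike here, whereas this result extends that to one amide-bearing aryl group. No available evidence gives a reason for this sameness.

The compounds shown leave open whether a carboxylic acid or a primary amine on the same phenyl ring would also stay within the scatter. They also leave open whether a smaller amide, one that keeps the amide hydrogen, would do so.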